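Swapping fluoro for methoxy at a second position

The compounds below may be only part of what the source reports. "The series", "measured", "known", "first", "only" and "open" are said of these compounds alone.

Three compounds sharing one core have been examined in an assay on isolated protein for binding affinity to 5-hydroxytryptamine receptor 1D (Homo sapiens); a higher number here means a weaker inhibitor, a lower number a stronger inhibitor. Compound 1 `Fc1cccc(-c2n[nH]cc2N2CCCNCC2)c1` carries a fluoro group and in this assay gives 2540 nM. Compound 2 `Fc1ccc(-c2n[nH]cc2N2CCCNCC2)cc1` holds the same atoms joined differently, and the difference between the two cores is not broken down here; in this assay compound 2 gives 2190 nM, a value within the usual scatter of that of compound 1. Compound 3 `COc1cccc(-c2n[nH]cc2N2CCCNCC2)c1` is compound 1 with a methoxy in place of fluoro on an aromatic carbon, meta to a large group (methoxy in place of fluoro on an aromatic carbon). In this assay compound 3 reaches a limit, > 10000 nM, not a number. Going by these compounds, that change made an at least 3.9-fold higher number from compound 1 to compound 3 (0.59 log units; beyond the scatter), a step whose full size stays open at the top because of the limit of > 10000 nM in this assay, at which 1 of the 3 values shown sits.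

Compound 4 `COc1ccc(-c2n[nH]cc2N2CCCNCC2)cc1` remains to be measured. It differs from compound 2 by the same kind of change (methoxy in place of fluoro on an aromatic carbon), though here the methoxy stands para to a large group rather than meta. For the measured compounds named here, compound 1 and compound 2 give values within the scatter of each other; the change from compound 1 to compound 3 is the only measured guide. The step expected here is a 3.9-fold higher number from compound 2 to compound 4 (0.59 log units; beyond the scatter), about the size of the earlier one. Compound 4 is estimated at 8500 nM in this assay, most likely between 3500 nM and 20000 nM, with a fair chance that only a limit is reported.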

Compound 4, inhibition constant: 3030 nM
Compound 4: the middle estimate sits 2.8-fold (0.45 log units) above what was measured; the measured number lies below the stated range.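

On the second core, methoxy in place of fluoro gave a 1.4-fold higher number from compound 2 to compound 4 (0.14 log units; within the scatter), so in this assay a swap that clearly raised the number on the core of compound 1 produced no step beyond the scatter on the core of compound 2. The same change therefore does not carry over between these two cores at one size, and the pair of steps differs by more than repeat measurements would explain: the same change on two cores in this assay, an at least 3.9-fold higher number (0.59 log units; beyond the scatter) from compound 1 to compound 3 and a 1.4-fold higher number (0.14 log units; within the scatter) from compound 2 to compound 4, at least 2.8-fold (0.45 log units) apart, beyond the scatter of two such steps This rests on a single pair for each core, so it shows that the effect of the swap depends on the core, but not why it does, and the true size of the step to compound 3 stays unknown, that compound's reading being a limit and not a number: the limit of > 10000 nM in this assay, at which 1 of the 4 values shown sits.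

The compounds shown leave open whether other groups in the same place, such as chloro, methyl or trifluoromethyl, would follow the pattern of compound 3 or that of compound 4 in this assay. They also leave open whether a hydroxyl or an amine there would give a step of a different size on either core.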